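Six More Chain Carbons on the Amide of Compound 1

This account rests on a few compounds, and the source may have more. Where it says the series, first, only, none or still open, it means among the compounds named here.

The two measured compounds, with their values in a functional assay on SW-620 cells (Homo sapiens) for cytotoxicity, read by MTT assay, with a stated time of 48 h; a lower number here means a stronger inhibitor, a higher number a weaker inhibitor:
compound 1, `CCCCCCCCCCCCNC(=O)[C@@H](NC(=O)c1ccco1)[C@@H](C)O`, gives 87500 nM
compound 2, `CCCCCCCCCCCCNC(=O)[C@@H](NC(=O)c1cccs1)[C@@H](C)O`, gives 29200 nM

For the measured compounds named here, compound 1 has the higher of the two numbers; the only neighbour, compound 2, differs from it by the step of a 3.0-fold lower number from compound 1 to compound 2 (0.48 log units; beyond the scatter), a modest change that comes from swapping the heteroaryl group on the carbonyl carbon.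

Compound 3, `CCCCCCCCCCCCCCCCCCNC(=O)[C@@H](NC(=O)c1ccco1)[C@@H](C)O`, keeps the furan-2-yl amide of compound 1 and changes only the saturated chain: hexyl in place of hydrogen on a saturated chain carbon, ten or more bonds along the chain from an amide-type nitrogen. Going by the values given here, the single measured step, from compound 1 to compound 2, touches the heteroaryl ring and not the chain, so no measured step bears on this change. There is no basis in the shown numbers for a direction, and compound 3 is therefore expected to land near compound 1 with a wide allowance either way, an expected step of a 1.3-fold lower number from compound 1 to compound 3 (0.10 log units; within the scatter). The estimate for compound 3 in this assay is 70000 nM, with a range from 20000 nM to 250000 nM.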

Compound 3, half-maximal inhibitory concentration: > 200000 nM
Compound 3 gave a limit, no number; the forecaster's own chance of this, stated with the estimate: 20%; middle value at least 2.8-fold (0.45 log units) from the limit.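

In this assay, the saturated chain now has a measured step of its own: hexyl in place of hydrogen on that chain gives an at least 2.2-fold higher number from compound 1 to compound 3 (0.35 log units; beyond the scatter). For the compounds shown here, the earlier step touched only the heteroaryl ring, so this is the first sign that this place on the chain is not silent, and that added chain carbons here raise the number in this furan-2-yl series rather than lower it. Compound 3 has > 200000 nM, which is a limit and not a number, so the step has a lower bound but no known size, and the reading rests on one value that sits at that limit: the limit of > 200000 nM in this assay, at which 1 of the 3 values shown sits.

The compounds shown leave open whether a chain shorter than that of compound 1 would lower the number, and whether an amine or a carboxylic acid at the far end of the chain would change the outcome. They also leave open whether the thiophen-2-yl amide of compound 2 would respond to the same hexyl change in the same direction.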